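The source may report more compounds than this note shows. Statements on the series, on what has been measured and on what is new or still open speak of the compounds shown alone.

Measured compounds in an ADME assay on L929 cells (Mus musculus) for cytotoxicity, read by resazurin assay, with a stated time of 72 h; on this read-out lower numbers stand for stronger inhibition and higher numbers for weaker inhibition:
compound 1, `O=C(/C=C/c1ccc2c(c1)B(O)OC2)c1ccc(C(F)(F)F)cc1`: > 10 ug/mL
compound 2, `O=C(/C=C/c1ccc2c(c1)B(O)OC2)c1ccc(O)cc1`: > 10 ug/mL
compound 3, `CCc1ccc(C(=O)/C=C/c2ccc3c(c2)B(O)OC3)cc1`: > 10 ug/mL

Each of these three values is a limit of this assay, not a number. All three sit at the limit of > 10 ug/mL in this assay, at which 3 of the 3 values shown sit, so compound 3 stands with the other two at that limit and nowhere above or below it can be read. The steps a step that the two limits leave unreadable from compound 1 to compound 3 and a step that the two limits leave unreadable from compound 2 to compound 3 are unreadable, as is a step that the two limits leave unreadable from compound 1 to compound 2. Compound 4, `O=C(/C=C/c1ccc2c(c1)B(O)OC2)c1ccc(Cl)cc1`, differs from compound 3 by chloro in place of ethyl on an aromatic carbon. Among the compounds with values here, no measured step yields a readable size, and every known value rests at the limit, so no step beyond the scatter is expected and a step that the limit leaves unreadable from compound 3 to compound 4 is the expected step. Compound 4 is expected at 15 ug/mL, between 8 ug/mL and 40 ug/mL, and most probably again only a limit is expected.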

Compound 4, half-maximal inhibitory concentration: > 10 ug/mL
Compound 4: only a limit was reported (the forecaster's own chance of this, stated with the estimate: 80%); the middle value is on the limit's open side.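

Compound 4 joins compound 1, compound 2 and compound 3 at a limit, so no step among the four can be read: the limit of > 10 ug/mL in this assay, at which 4 of the 4 values shown sit.

The compounds shown leave open how far any of them lies beyond that limit, and whether these four groups differ at all.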